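The compounds below may be only part of what the source reports. "The series", "measured", "known", "first", "only" and "open" are said of these compounds alone.

Compound 2 `O=C(NO)c1ccc(NCc2nc(-c3cccc(Cl)c3)nn2-c2ccccc2)cc1` in an assay on Sf9 cells for inhibition of protein deacetylase HDAC6 (Homo sapiens), read by fluorescence, with a stated time of 40 min, tested at 100 nM (on this read-out lower numbers stand for less inhibition and higher numbers for more inhibition at the one concentration tested (going by the name of the read-out)), gives 61.2%. Among the measured compounds shown here, the only comparator is compound 1 `O=C(NO)c1ccc(NCc2nc(-c3ccc(Br)cc3)nn2-c2ccccc2)cc1`, which in this assay gives 54.7%; the step of a number 6.5 percentage points higher from compound 1 to compound 2 (within the scatter) sets compound 2 alongside compound 1 rather than apart from it. Compound 3 `O=C(NO)c1ccc(NCc2nc(-c3ccc(F)cc3)nn2-c2ccccc2)cc1` differs from compound 2 by 4-fluorophenyl in place of 3-chlorophenyl on an aromatic carbon. For the measured compounds named here, the one measured step, a swap of one halophenyl for another, stayed within the scatter, so for this second halophenyl swap no step beyond the scatter is expected in this assay. The estimate for compound 3 is 54%, range 38% to 70%, which means an expected step of a number 7.2 percentage points lower from compound 2 to compound 3 (within the scatter).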

Compound 3, a percentage reported as inhibition, at one concentration (the size of the read-out at that concentration, not a potency): 70.9%
Compound 3: middle estimate off by 16.9 percentage points, on the low side, and the stated range ends below it.
By their numbers in this assay, from the lowest: compounds 1, 2 and 3 (each within the scatter of the next, the first and the last beyond it).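

In this assay, among the compounds shown here, the halogen on this phenyl now separates two compounds: a number 16.2 percentage points higher from compound 1 to compound 3 (beyond the scatter) is the first step beyond the scatter, with fluoro in place of bromo on the same ring carbon. The change to 4-fluorophenyl from 3-chlorophenyl, read as a number 9.7 percentage points higher from compound 2 to compound 3 (within the scatter) and so within the scatter, does not set compound 2 apart from compound 3. Nothing available bears on the reason for the gap. Still open, as far as these compounds go, is where 4-chlorophenyl would fall relative to compound 1 and compound 3. Also open, from the compounds shown here alone, is whether a methoxy group or an amine on this phenyl would hold the read-out.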